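Notes on compound 4: amino in place of nitro

This account rests on a few compounds, and the source may have more. Where it says the series, first, only, none or still open, it means among the compounds named here.

Measured so far in an assay on ileum (strain Hartley) with 5-hydroxytryptamine receptor 3A (Cavia porcellus) as the target; a higher number here means a larger maximal response, a lower number a smaller maximal response:
compound 1 `COc1ccc2oc(N3CCN(C)CC3)nc2c1`, 0.78
compound 2 `CN1CCN(c2nc3cc([N+](=O)[O-])ccc3o2)CC1`, 0.52
compound 3 `CCc1cc(Cl)cc2nc(N3CCN(C)CC3)oc12`, 0.17

Compound 2 stands second of the three. Its nearest neighbour is compound 1, reached by a number 0.26 lower from compound 1 to compound 2 (beyond the scatter); compound 3, with 0.17, is the furthest away, and that gap also lies beyond the scatter.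

Compound 4 `CN1CCN(c2nc3cc(N)ccc3o2)CC1` differs from compound 2 in one place: amino in place of nitro on an aromatic carbon. Within the data shown here, no measured pair shows amino entering anywhere, so the only step that bears on it is the one at the same aromatic carbon, nitro in place of methoxy, which gave a number 0.26 lower from compound 1 to compound 2 (beyond the scatter). That step shows the position itself can move this assay by a modest amount in either direction. With nothing to fix the sign for amino, the expectation is a small upward step, a number 0.10 higher from compound 2 to compound 4 (within the scatter), landing between compound 2 and compound 1, and the estimate for compound 4 is 0.62, within 0.4 to 0.85.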

Compound 4, intrinsic activity: the largest response reached, as a fraction of the reference agonist's: 0.76
Compound 4: middle estimate off by 0.14, on the low side, within the range that was stated.
By their numbers in this assay, from the lowest: compound 3; then compound 2; then compounds 4 and 1 (each within the scatter of the next).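

At this aromatic carbon in this assay, amino in place of nitro gives a number 0.24 higher from compound 2 to compound 4 (beyond the scatter), so the position moves upward as well as downward, and the fall seen with nitro does not depend on losing methoxy alone. Amino in place of methoxy gives a number 0.020 lower from compound 1 to compound 4 (within the scatter), so these two groups cannot be told apart in this read-out, and of the three groups at this carbon only nitro stands apart, with its steps to both others beyond the scatter. No measurement is available that could account for this separation.

Open, going by these compounds, is whether the high response extends to other groups at this carbon, such as hydroxyl, methyl or acetamido. With more than one place changed from the others, compound 3 at 0.17 adds nothing on this carbon.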